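A few compounds are considered here, and "the series" means these few. Any claim that something is new, unique, unknown or untested is made for them only; others in the source may bear on it.

Three compounds share one core and differ only in the group carried on the outer ring. Compound 1 `CCCCOC(=O)NS(=O)(=O)c1sc(CC(C)C)cc1-c1ccc(Cn2cccn2)cc1` gives 2.3 nM in an assay on membranes from uterus for displacement of a labelled ligand from Angiotensin type II receptor (Sus scrofa), with a stated time of 1.5 h; on this read-out lower numbers stand for stronger inhibition and higher numbers for weaker inhibition. Compound 2 `CCCCOC(=O)NS(=O)(=O)c1sc(CC(C)C)cc1-c1ccc(C(=O)c2ncco2)cc1` gives 13.8 nM, and compound 3 `CCCCOC(=O)NS(=O)(=O)c1sc(CC(C)C)cc1-c1ccc(CN2CCCC2=O)cc1` gives 3.5 nM. Compound 3 therefore stands between the other two: its gap to compound 1 is within the scatter, while the step of a 3.9-fold lower number from compound 2 to compound 3 (0.60 log units; beyond the scatter) is beyond it. The step of a 6.0-fold higher number from compound 1 to compound 2 (0.78 log units; beyond the scatter) shows the same kind of move, from a group joined through a saturated carbon to a group joined through a carbonyl, raising the number.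

Compound 4 `CCCCOC(=O)NS(=O)(=O)c1sc(CC(C)C)cc1-c1ccc(C(=O)c2cccs2)cc1` has not yet been measured. It arises from compound 3 by the change ((thiophen-2-yl)carbonyl in place of (2-oxopyrrolidin-1-yl)methyl on an aromatic carbon). This change again replaces a group joined through a saturated carbon with a group joined through a carbonyl, so the two measured steps that bear on it, one rising and one falling, both point the same way for this direction. A modest rise in the number is expected, of about a 2.9-fold higher number from compound 3 to compound 4 (0.46 log units; beyond the scatter), because a 3.9-fold lower number from compound 2 to compound 3 (0.60 log units; beyond the scatter) ran the other way for the closely related swap. Compound 4 is thus estimated at 10 nM, with a likely range from 4 nM to 25 nM.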

Compound 4, inhibition constant: 18.8 nM
Beside the measured number, compound 4's estimate is 1.9-fold (0.27 log units) below it, within the range that was stated.
By their numbers in this assay, from the lowest: compounds 1 and 3 (each within the scatter of the next); then compounds 2 and 4 (each within the scatter of the next).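

Within the data shown here, compound 2 and compound 4 cannot be told apart (a 1.4-fold higher number from compound 2 to compound 4 (0.13 log units; within the scatter)), so with the carbonyl link kept, thiophen-2-yl and 1,3-oxazol-2-yl give matching results, and a single carbonyl-linked ring is no longer the only evidence for that link. Both compounds joined through a saturated carbon sit clearly lower than compound 4 (a 5.4-fold higher number from compound 3 to compound 4 (0.73 log units; beyond the scatter) and an 8.2-fold higher number from compound 1 to compound 4 (0.91 log units; beyond the scatter)), and among these four compounds none goes against the pairing of the carbonyl link with the higher numbers, although in these two steps the ring changes together with the link. Nothing measured here gives a reason for this difference at the position on the six-membered aromatic ring.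

No two compounds shown carry the same ring on both kinds of link, so whether a (thiophen-2-yl)methyl group would fall with compound 1 and compound 3 or with compound 2 and compound 4 remains open. From the compounds shown here alone, how a carboxylic acid or a simple amine on this aromatic carbon would compare with these ring-bearing groups also remains open.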